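A few compounds are considered here, and "the series" means these few. Any claim that something is new, unique, unknown or untested is made for them only; others in the source may bear on it.

Three compounds sharing one core were tested in a functional assay on HCT-116 cells (Homo sapiens) for inhibition, read by MTT assay, with a stated time of 72 h; on this read-out higher numbers stand for weaker inhibition and lower numbers for stronger inhibition. Compound 1 `O=c1oc2cc(-c3cnc4[nH]ccc4c3)ccc2n1Cc1ccc(F)cc1` gives 5990 nM. Compound 2 `COc1cccc(Cn2c(=O)oc3cc(-c4cnc5[nH]ccc5c4)ccc32)c1` gives 5000 nM, and compound 3 `Cc1cccc(Cn2c(=O)oc3cc(-c4cnc5[nH]ccc5c4)ccc32)c1` gives 5120 nM. The three numbers sit within the scatter of one another: a 1.2-fold lower number from compound 1 to compound 2 (0.08 log units; within the scatter), a 1.2-fold lower number from compound 1 to compound 3 (0.07 log units; within the scatter) and a 1.0-fold higher number from compound 2 to compound 3 (0.01 log units; within the scatter). Compound 4 `COc1cccc(Cn2c(=O)oc3cc(-c4ccc5c(c4)CCN5)ccc32)c1` differs from compound 2 by a group of 9 heavy atoms (8 carbon, 1 nitrogen; one five-membered non-aromatic ring with 1 hetero atom, one six-membered aromatic ring of carbon only) in place of a group of 9 heavy atoms (7 carbon, 2 nitrogen; one five-membered aromatic ring with 1 hetero atom, one six-membered aromatic ring with 1 hetero atom), on an aromatic carbon. Within the data shown here, none of the measured steps touches this part of the molecule; each only swaps the group on the saturated chain carbon bound to an aromatic nitrogen. Those swaps stayed within the scatter, so they say nothing about how this assay responds to a change of the bicyclic group. Compound 4 is therefore expected to give 15000 nM, within 5000 nM to 50000 nM, which would be a 3.0-fold higher number from compound 2 to compound 4 (0.48 log units; beyond the scatter).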

Compound 4, half-maximal inhibitory concentration: > 100000 nM
Compound 4 was reported as a limit; the forecaster's own chance of this, stated with the estimate: 15%; at least 6.6-fold (0.82 log units) between middle value and limit.
By their numbers in this assay, from the lowest: compounds 2, 3 and 1 (each within the scatter of the next). At a limit, above all of these: compound 4.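

In this assay, among these compounds, this aromatic carbon is the first place where a change moves the result beyond the scatter: 2,3-dihydro-1H-indol-5-yl in place of the earlier group gives an at least 20-fold higher number from compound 2 to compound 4 (1.30 log units; beyond the scatter). The swaps on the saturated chain carbon showed no such response. The value of compound 4 is a limit: the limit of > 100000 nM in this assay, at which 1 of the 4 values shown sits.

The entering group differs in both its five-membered and six-membered rings, and the compounds shown do not separate those two changes. From the compounds shown here alone, how a simple phenyl, or a phenyl carrying an amine, would fare at this position remains open.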